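A few compounds are considered here, and "the series" means these few. Any claim that something is new, unique, unknown or untested is made for them only; others in the source may bear on it.

Compound 3 `Cc1cc(C)c(CN2CCc3c(Cl)cc([C@H](CO)[C@@H]4CCCO4)c(Cl)c3C2=O)c(=O)[nH]1` sits, in an ADME assay on microsomes from liver (Homo sapiens) for metabolic stability, read by LC-MS, using NADPH, with stated times of 10 min and 45 min, tested at 1 uM (a higher number here means faster removal of the compound, a lower number slower removal), at 37.6 uL/min. Its nearest neighbour is compound 1 `Cc1cc(C)c(CN2CCc3c(Cl)cc([C@H](CO)[C@H]4CCOC4)c(Cl)c3C2=O)c(=O)[nH]1`, which gives 21.3 uL/min; the step of a 1.8-fold higher number from compound 1 to compound 3 (0.25 log units; within the scatter) changes the saturated ring from oxolan-3-yl to oxolan-2-yl. Compound 2 `Cc1cc(C)c(CN2CCc3c(Cl)cc(C(CO)c4ccon4)c(Cl)c3C2=O)c(=O)[nH]1` has several entries, at 22.7 uL/min; 21.2 uL/min (2 entries), and these repeats the several entries of compound 2 in this assay, 22.7 uL/min; 21.2 uL/min (2 entries) show how far one number can drift from another without any real difference. Compound 4 `Cc1cc(C)c(CN2CCc3c(Cl)cc([C@@H](CO)[C@@H]4CCOC4)c(Cl)c3C2=O)c(=O)[nH]1` is the next structure. The change from compound 3 to compound 4 is a group of 8 heavy atoms (6 carbon, 2 oxygen; one five-membered non-aromatic ring with 1 hetero atom) in place of a group of 8 heavy atoms (6 carbon, 2 oxygen; one five-membered non-aromatic ring with 1 hetero atom), on an aromatic carbon; the two have the same atoms, joined differently, with the two defined stereocentres set otherwise. Among the compounds with values here, the only step measured on this part of the molecule, from compound 1 to compound 3, stayed within the scatter, so for compound 4 no shift beyond the scatter is expected in this assay, and the estimated step of a 1.5-fold lower number from compound 3 to compound 4 (0.18 log units; within the scatter) is small. Compound 4 is therefore expected to give about 25 uL/min, in a range from 12 uL/min to 50 uL/min.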

Compound 4, intrinsic clearance in a liver preparation (reported as CLH), per the amount of preparation that the assay uses in the liver assay: 25.3 uL/min
The estimate for compound 4 lay 1.0-fold (0.01 log units) below the measured number, within the range that was stated.
By their numbers in the liver assay, from the lowest: compounds 1, 4 and 3 (each within the scatter of the next).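

In the liver assay, inverting both stereocentres gives a 1.2-fold higher number from compound 1 to compound 4 (0.07 log units; within the scatter), and the change of ring attachment together with the changed configuration gives a 1.5-fold lower number from compound 3 to compound 4 (0.17 log units; within the scatter). Across these three compounds, then, neither the attachment of the oxolane ring nor its drawn configuration moves the number beyond the scatter, which the single earlier step could not show for configuration. Within the data shown here, the same change does register elsewhere: in a physicochemical assay for lipophilicity, at pH 7.4 (a higher number here means a more lipophilic compound, a lower number a more polar compound), compound 3 gives 2.4 and compound 4 gives 2, a gap beyond the scatter with no counterpart in the liver assay.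

One such pair cannot tell whether the two read-outs follow each other in this series. As far as these compounds go, it also stays open whether an amine or a carboxylic acid at this position would shift the liver assay beyond the scatter.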